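The source may report more compounds than this note shows. Statements on the series, on what has been measured and on what is new or still open speak of the compounds shown alone.

In a physicochemical assay for lipophilicity, read by HPLC, using the shake flask method (on this read-out higher numbers stand for higher lipophilicity and lower numbers for lower lipophilicity), compound 1 `C/C(=N\C#N)N(Cc1ccccc1)Cc1ccc(Cl)nc1` gives 2.11. Compound 3 `CCCC/C(=N\C#N)N(C)Cc1ccc(Cl)nc1`, at 1.87, lies within the usual scatter of that number, while compound 2 `CC/C(=N\C#N)N(C)Cc1ccc(Cl)nc1`, at 1.12, lies clearly lower. Compound 4 `CCCN(Cc1ccc(Cl)nc1)/C(C)=N/C#N` has not yet been measured. Its difference from compound 1 is ethyl in place of phenyl on a saturated chain carbon bound to an amine nitrogen, or benzyl to propyl. For the measured compounds named here, the only measured step that offers guidance sits elsewhere on the molecule and also swaps in ethyl, with a number 0.75 log units higher from compound 2 to compound 3 (beyond the scatter). Going by the values given here, no measured step removes phenyl, so this is a loose guide. A modest downward move in this assay is expected, and the estimated step is a number 0.61 log units lower from compound 1 to compound 4 (beyond the scatter). For compound 4 the estimated value is 1.5, with an expected range from 1.2 to 1.8.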

Compound 4, partition coefficient: 1.62
Compound 4: the middle estimate sits 0.12 log units below what was measured; the measured number falls inside the stated range.
By their numbers in this assay, from the lowest: compound 2; then compounds 4, 3 and 1 (each within the scatter of the next, the first and the last beyond it).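

For the compounds shown here, on a saturated chain carbon bound to an amine nitrogen, ethyl in place of phenyl gives the first measured change at this position, with a number 0.49 log units lower from compound 1 to compound 4 (beyond the scatter) in this assay. The read-out therefore responds to a change at this position, here one in which a six-membered aromatic ring of carbon leaves and no ring enters. No measurement shown explains the size of this move.

A single swap cannot show how the number follows the group at this position. From the compounds shown here alone, whether a longer chain, an amine or a carboxylic acid in the same place would move the number further, and in which direction, remains open.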